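The source may report more compounds than this note shows. Statements on the series, on what has been measured and on what is new or still open speak of the compounds shown alone.

Measured in an ADME assay on MT4 cells (Homo sapiens) for cytotoxicity, read by MTT assay, with a stated time of 5 days; a higher number here means that more compound is tolerated, a lower number that less compound is tolerated:

compound 1 `Cc1cc(C#N)cc(C)c1Oc1nc(NC2CCCN(Cc3ccc(S(N)(=O)=O)cc3)C2)nc2ccsc12`: 1170 nM
compound 2 `Cc1cc(C#N)cc(C)c1Oc1nc(NC2CCC(NCc3ccc([N+](=O)[O-])cc3)CC2)nc2ccsc12`: 54400 nM

Of these two, compound 2 stands highest at 54400 nM, and the gap down to compound 1 at 1170 nM lies well beyond the scatter. The two differ in more than one place, so no single change can be read from them.

The next compound is compound 3 `Cc1cc(C#N)cc(C)c1Oc1nc(NC2CCC(NCc3cccc(C(F)(F)F)c3)CC2)nc2ccsc12`, which departs from compound 2 at one place only: 3-(trifluoromethyl)phenyl in place of 4-nitrophenyl on a saturated chain carbon bound to an amine nitrogen. It carries 3-(trifluoromethyl)phenyl in place of 4-nitrophenyl on a saturated chain carbon bound to an amine nitrogen, and the rest of the structure stays the same. Among the compounds with values here, no measured pair shows what this change does. Within the data shown here, the expectation therefore rests on position alone: compound 2 at 54400 nM is the higher of only two values, so a fall is thought more likely than a rise, probably of moderate size and beyond the scatter. The expected change is a 3.9-fold lower number from compound 2 to compound 3 (0.59 log units; beyond the scatter). The estimate for compound 3 is 14000 nM, with an expected range of 3500 nM to 55000 nM.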

Compound 3, half-maximal cytotoxic concentration: 707 nM
Estimate against measurement, compound 3: 20-fold (1.30 log units) above; measured number below the stated range.
By their numbers in this assay, from the lowest: compounds 3 and 1 (each within the scatter of the next); then compound 2.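

In this assay, placing 3-(trifluoromethyl)phenyl in place of 4-nitrophenyl on a saturated chain carbon bound to an amine nitrogen gives a 77-fold lower number from compound 2 to compound 3 (1.89 log units; beyond the scatter), a large step and the first in this set that can be tied to a single place. It shows that this position is far from silent: with the rest of the structure unchanged, the identity of the aromatic group alone moves the cytotoxic concentration well beyond the scatter, something the earlier pair, differing in more than one place, could not show. No evidence is at hand that accounts for the size of this step.

The step replaces one substituent with another and also changes where it stands on the phenyl ring, so the compounds shown do not separate these two changes; 4-(trifluoromethyl)phenyl or 3-nitrophenyl at this place would pull them apart. Going by these compounds, it also remains open how an unsubstituted phenyl, or a phenyl carrying a carboxylic acid or an amine, would fall relative to compound 2 and compound 3.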